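Replacing the methylsulfanyl group of compound 2

The source may report more compounds than this note shows. Statements on the series, on what has been measured and on what is new or still open speak of the compounds shown alone.

Compound 1 `CSc1ccccc1CSc1nc(-c2ccc(F)cc2)c(-c2ccncc2)[nH]1` gives 6700 nM
Compound 2 `CSc1ccc(O)c(CSc2nc(-c3ccc(F)cc3)c(-c3ccncc3)[nH]2)c1` gives 740 nM

In a functional assay (Homo sapiens) for inhibition (a higher number here means a weaker inhibitor, a lower number a stronger inhibitor), compound 2 has the lowest number of the two. Within the data shown here, compound 3 `C[S+]([O-])c1ccc(O)c(CSc2nc(-c3ccc(F)cc3)c(-c3ccncc3)[nH]2)c1` differs from it at one place, on an aromatic carbon: a group of 3 heavy atoms (1 carbon, 1 oxygen, 1 sulfur; no ring) in place of a group of 2 heavy atoms (1 carbon, 1 sulfur; no ring), on an aromatic carbon and no measured step covers this replacement. Among the measured compounds shown here, the only measured step is a 9.1-fold lower number from compound 1 to compound 2 (0.96 log units; beyond the scatter) but that is a different replacement and sets neither size nor direction here. No change beyond the scatter is expected, with wide uncertainty. The expected step is a 1.1-fold higher number from compound 2 to compound 3 (0.03 log units; within the scatter) in this assay on this reasoning. Compound 3 is estimated at 800 nM with an expected range of 200 nM to 3000 nM around that figure.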

Compound 3, half-maximal inhibitory concentration: 1000 nM
Beside the measured number, compound 3's estimate is 1.3-fold (0.10 log units) below it; measured number inside the range.
By their numbers in this assay, from the lowest: compounds 2 and 3 (each within the scatter of the next); then compound 1.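

In this assay, adding an oxygen to the sulfur at this aromatic carbon, para to a hydroxy group, gives a 1.4-fold higher number from compound 2 to compound 3 (0.13 log units; within the scatter) and so no change beyond the scatter. The advantage over the compound lacking the hydroxy group persists, at a 6.7-fold lower number from compound 1 to compound 3 (0.83 log units; beyond the scatter) and thus beyond the scatter. No measurement at hand accounts for this tolerance. Going by these compounds, whether the position would also accept a methylsulfonyl group, an amine, a carboxylic acid or a longer chain remains open. So does whether any group here could move the number beyond the scatter in either direction.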